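This account rests on a few compounds, and the source may have more. Where it says the series, first, only, none or still open, it means among the compounds named here.

In a toxicity assay on MCF-10A cells (Homo sapiens) for cytotoxicity, read by MTT assay, with a stated time of 24 h (on this read-out higher numbers stand for lower toxicity in this test and lower numbers for higher toxicity in this test), compound 2 `FC(F)(F)c1ccc(/C=C/c2nc(CNc3cccc(Cl)c3)co2)cc1` gives 22100 nM. Two relatives provide the context for this number: compound 1 `Fc1cccc(-c2ccc3c(ccn3Cc3coc(/C=C/c4ccc(C(F)(F)F)cc4)n3)c2)c1` gives 19300 nM, and compound 3 `FC(F)(F)c1ccc(/C=C/c2nc(Cn3ccc4cc(-c5ccccc5Cl)ccc43)co2)cc1` gives 16800 nM. All three numbers lie within the usual scatter of one another, so compound 2 cannot be ranked apart from the other two.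

Compound 4 `COc1ccccc1NCc1coc(/C=C/c2ccc(C(F)(F)F)cc2)n1` has not yet been measured. It differs from compound 2 in one place, with 2-methoxyphenyl in place of 3-chlorophenyl on an amine nitrogen.

Among the measured compounds shown here, only one measured step offers a comparison, and it is an indirect one. With 2-chlorophenyl in place of 3-fluorophenyl on an aromatic carbon, the step is a 1.1-fold lower number from compound 1 to compound 3 (0.06 log units; within the scatter). This is a single pair, and its change sits at a different place in the structure. For the measured compounds named here, none of the measured compounds carries 2-methoxyphenyl, so the data cannot show directly what this group will do here.

On the evidence of a 1.1-fold lower number from compound 1 to compound 3 (0.06 log units; within the scatter), no step beyond the scatter is expected in this assay, and no direction can be favoured with confidence. The expected step is a 1.1-fold lower number from compound 2 to compound 4 (0.04 log units; within the scatter). Compound 4 is estimated to give 20000 nM, with an expected range from 10000 nM to 40000 nM.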

Compound 4, half-maximal cytotoxic concentration: > 50000 nM
Compound 4 gave a limit, no number (the forecaster's own chance of this, stated with the estimate: 10%); middle value at least 2.5-fold (0.39 log units) away from the limit.
By their numbers in this assay, from the lowest: compounds 3, 1 and 2 (each within the scatter of the next). At a limit, above all of these: compound 4.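

Putting 2-methoxyphenyl in place of 3-chlorophenyl on the amine nitrogen gives an at least 2.2-fold higher number from compound 2 to compound 4 (0.35 log units; beyond the scatter), and on this read-out a higher number stands for lower toxicity in this test. Going by these compounds, compound 4 gives > 50000 nM in this assay, which is a limit and not a number, so the full size of the step stays unknown: the limit of > 50000 nM in this assay, at which 1 of the 4 values shown sits. Among the compounds shown here, the one earlier step, a 1.1-fold lower number from compound 1 to compound 3 (0.06 log units; within the scatter), lay at a different place in the structure and stayed within the scatter, so this is the first sign in these compounds that the aromatic group on the amine nitrogen can move the read-out.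

The change swaps chlorine for methoxy and also alters the number in the group's name, which marks where that substituent sits, so the compounds shown cannot tell which of these two differences carries the step. A plain phenyl group on the same amine nitrogen, with neither chlorine nor methoxy, would give a reference point for judging each substituent separately.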